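Diethylamino to triazolyl step in an antiproliferative series

The compounds below may be only part of what the source reports. "The series", "measured", "known", "first", "only" and "open" are said of these compounds alone.

Measured compounds:
compound 1 `CC(=O)O[C@]1(C)/C=C/C(=O)/C(CO)=C\C[C@](C)(CCC=C(C)C)/C=C/[C@H]1OC(=O)C=C(C)C`: 2010 nM
compound 2 `CCN(CC)C/C1=C/C[C@](C)(CCC=C(C)C)/C=C/[C@@H](OC(=O)C=C(C)C)[C@](C)(O)/C=C/C1=O`: 270 nM
compound 3 `CC(C)=CCC[C@]1(C)/C=C/[C@@H](OC(=O)C=C(C)C)[C@](C)(O)/C=C/C(=O)/C(C[Si](c2ccccc2)(c2ccccc2)C(C)(C)C)=C\C1`: 20700 nM

In a functional assay on SW480 cells (Homo sapiens) for antiproliferative activity, read by MTT assay, with a stated time of 48 h (a higher number here means a weaker inhibitor, a lower number a stronger inhibitor), compound 2 gives 270 nM, the lowest number of the three. Compound 1 gives 2010 nM, which lies beyond the scatter above compound 2, and compound 3 gives 20700 nM, further above still and also beyond the scatter. On these numbers compound 2 is the strongest inhibitor of the set.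

Compound 4 `CC(C)=CCC[C@]1(C)/C=C/[C@@H](OC(=O)C=C(C)C)[C@](C)(O)/C=C/C(=O)/C(Cn2cc(CO)nn2)=C\C1` is the next compound for this assay. Against compound 2 the change is 4-(hydroxymethyl)-1H-1,2,3-triazol-1-yl in place of diethylamino on a saturated chain carbon bound to a double-bonded ring carbon. No measured pair differs in this one place alone, so the size of the step is not shown by the data. Compound 1 and compound 3 differ from compound 2 in more than one place and so bound the expectation only loosely, but both carry higher numbers than compound 2 in this assay, and nothing measured suggests that any replacement of the diethylamino group keeps the number of compound 2. The expected step from compound 2 to compound 4 is therefore toward a higher number, beyond the scatter, as a 5.6-fold higher number from compound 2 to compound 4 (0.74 log units; beyond the scatter). Compound 4 is estimated at 1500 nM, within a range of 400 nM to 6000 nM.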

Compound 4, half-maximal inhibitory concentration: 2870 nM
Compound 4: middle estimate off by 1.9-fold (0.28 log units), on the low side; the range from low to high includes it.
By their numbers in this assay, from the lowest: compound 2; then compounds 1 and 4 (each within the scatter of the next); then compound 3.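

In this assay, within the data shown here, the exchange on a saturated chain carbon bound to a double-bonded ring carbon gives the first step in this set that can be read in one place alone: an 11-fold higher number from compound 2 to compound 4 (1.03 log units; beyond the scatter). The number at this position therefore depends strongly on the group it carries, and a diethylamino group cannot be replaced by 4-(hydroxymethyl)-1H-1,2,3-triazol-1-yl without a large shift. Several things change at once, since the entering group brings an aromatic ring, a hydrogen-bond donor and more hydrogen-bond acceptors, and nothing available here gives a reason for the step or assigns it to any one of these features.

The compounds shown leave open whether the higher number follows from losing the diethylamino group or from the triazole and its hydroxymethyl substituent. A dimethylamino or piperidine group at this position would test how much of the amine's shape the number tolerates, and a 1,2,3-triazole with no hydroxymethyl substituent, or with a longer chain ending in a hydroxyl group, would separate the ring from its substituent.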